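Methyl for phenyl on the imine nitrogen: cytotoxicity notes

A few compounds are considered here, and "the series" means these few. Any claim that something is new, unique, unknown or untested is made for them only; others in the source may bear on it.

Compound 1 `CN1C(=O)/C(=C/c2ccn(Cc3ccccc3)c2)S/C1=N\c1ccccc1` and compound 3 `C/N=C1\S/C(=C\c2ccn(Cc3ccccc3)c2)C(=O)N1C` share one core; compound 2 `CN1C(=O)/C(=C/c2cnn(-c3ccccc3C(F)(F)F)c2)S/C1=N\c1ccccc1` and the not yet measured compound 4 `C/N=C1\S/C(=C\c2cnn(-c3ccccc3C(F)(F)F)c2)C(=O)N1C` share another. How the two cores differ is not broken down here.

In an ADME assay on L6 cells (Rattus norvegicus) for cytotoxicity, read by microscopy and resazurin assay, with a stated time of 72 h (on this read-out higher numbers stand for an effect only at larger amounts of compound and lower numbers for an effect already at smaller amounts), compound 1 gives > 240000 nM, a limit of the assay and not a number. In this assay compound 3 also stops at a limit, > 290000 nM. The change between them is methyl in place of phenyl on a double-bonded nitrogen and the step that the two limits leave unreadable from compound 1 to compound 3 cannot be read because the limit of > 240000 nM in this assay, at which 1 of the 3 values shown sits, and the limit of > 290000 nM in this assay, at which 1 of the 3 values shown sits, bound both ends. In this assay, among the measured compounds shown here, compound 2 gives 180000 nM, the only number among the three compounds measured so far.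

Compound 4 carries the same change relative to compound 2, (methyl in place of phenyl on a double-bonded nitrogen). No readable step is available for this change, so the expectation is a step of about a 1.2-fold higher number from compound 2 to compound 4 (0.07 log units; within the scatter), within the usual scatter. For compound 4 the estimate is 210000 nM, with a range from 100000 nM to 320000 nM, and a fair chance that only a limit is reported.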

Compound 4, half-maximal effective concentration: 34000 nM
Compound 4: middle estimate off by 6.2-fold (0.79 log units), on the high side, outside the stated range (below it).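

In this assay, methyl in place of phenyl on a double-bonded nitrogen gives a 5.3-fold lower number from compound 2 to compound 4 (0.72 log units; beyond the scatter), a step beyond the usual scatter on the core shared by compound 2 and compound 4. The same change on the other core, from compound 1 to compound 3, cannot be read, as the values of both compounds are limits of the assay and not numbers. The series therefore gives one readable step on one core: it shows that the change can lower the number there, but it does not show whether the change carries over to the core of compound 1, in direction or in size.

The compounds shown leave open how other groups on the double-bonded nitrogen, such as ethyl, a longer chain or a chain ending in an amine, would compare with methyl and phenyl on either core. On these data alone, it also remains open whether the drop seen with compound 4 belongs to methyl in general or only to this core.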